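The compounds below may be only part of what the source reports. "The series", "measured", "known", "first", "only" and "open" are said of these compounds alone.

In a functional assay on COLO 205 cells (Homo sapiens) for inhibition, read by MTT assay, with a stated time of 48 h (on this read-out lower numbers stand for stronger inhibition and higher numbers for weaker inhibition), three compounds have been measured so far.

Compound 1, `COc1cc(OC)c(OC)cc1/C=C/C(=O)c1cc(OC)c(OC)c(OC)c1`, gives 18600 nM.
Compound 2, `COc1cc(C(=O)/C=C/c2ccc(O)cc2)cc(OC)c1OC`, gives 29700 nM.
Compound 3, `COc1cc(/C=C/C(=O)c2cc(OC)c(OC)c(OC)c2)ccc1O`, reaches only the limit of this assay, > 100000 nM.

The values of compound 1 and compound 2 lie within the usual scatter of each other, so nothing separates them. For the measured compounds named here, the one measured step is an at least 3.3-fold lower number from compound 3 to compound 2 (0.52 log units; beyond the scatter); the change is hydrogen in place of methoxy on an aromatic carbon. Its size is open at one end because the limit of > 100000 nM in this assay, at which 1 of the 3 values shown sits, shows the value of compound 3 to be a limit rather than a number. The difference between the core of compound 1 and the core of compound 3 is not broken down here.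

Compound 4, `COc1ccc(/C=C/C(=O)c2cc(OC)c(OC)c(OC)c2)c(OC)c1`, is still to be measured. It arises from compound 1 by hydrogen in place of methoxy on an aromatic carbon. Going by the values given here, this is the same kind of change as the one from compound 3 to compound 2, though the surroundings differ: in the earlier case the carbon that loses its methoxy is ortho to a hydroxy group and meta to a large group, whereas in compound 4 it is ortho to a methoxy group, meta to a large group and para to a methoxy group. Since the earlier step lowered the number in this assay, a step of similar direction is expected, a 2.1-fold lower number from compound 1 to compound 4 (0.32 log units; beyond the scatter), beside the at least modest an at least 3.3-fold lower number from compound 3 to compound 2 (0.52 log units; beyond the scatter). Compound 4 is therefore expected to give about 9000 nM, somewhere between 3000 nM and 35000 nM.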

Compound 4, half-maximal inhibitory concentration: 82500 nM
For compound 4 the middle estimate is 9.2-fold (0.96 log units) below the measured one; measured number outside the range, above it.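

In this assay, hydrogen in place of methoxy on an aromatic carbon gives a 4.4-fold higher number from compound 1 to compound 4 (0.65 log units; beyond the scatter), so on the core of compound 1 the change runs in the opposite direction to the earlier step. Knowing the direction of this change on one core therefore did not give its direction on the other core in this series: the same change on two cores in this assay, an at least 3.3-fold lower number (0.52 log units; beyond the scatter) from compound 3 to compound 2 and a 4.4-fold higher number (0.65 log units; beyond the scatter) from compound 1 to compound 4, at least 14-fold (1.17 log units) apart, beyond the scatter of two such steps This does not show why the two steps differ, as the methoxy group lost also sits in different surroundings in the two pairs, so the effect of the core cannot be separated from the effect of the place, and the earlier step stays open at one end, as the value of compound 3 is a limit and not a number: the limit of > 100000 nM in this assay, at which 1 of the 4 values shown sits.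

The compounds shown leave open what other groups on this aromatic carbon would do on the core of compound 1, for example an amine, a fluorine atom or a longer chain such as ethoxy. On these data alone, whether the opposite directions would recur on a third core also stays open.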